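Swapping an Amidoxime Arm for a Nitrophenyl Arm

The source may hold more compounds than are shown below. What is called first, only, known or untested is meant among the compounds shown, and "the series" means these compounds.

Three compounds sharing one core have been examined in an ADME assay on J774.A1 cells (Mus musculus) for cytotoxicity, read by MTT assay, with a stated time of 72 h; a higher number here means that more compound is tolerated, a lower number that less compound is tolerated. Compound 1 `CC1(Cc2ccccc2)CC(S(=O)(=O)c2cccc(C(F)(F)F)c2)=C(c2ccc(/C(N)=N\O)cc2)O1` gives 14500 nM. Compound 3 `COc1ccc(C2(c3ccccc3)CC(S(=O)(=O)c3ccc(F)cc3)=C(c3ccc(/C(N)=N\O)cc3)O2)cc1` gives 11300 nM. Compound 2 `CC1(c2ccc(-c3ccc(/C(N)=N\O)cc3)cc2)CC(S(=O)(=O)c2ccc(F)cc2)=C(c2ccc(/C(N)=N\O)cc2)O1` gives 3940 nM, the lowest of the three numbers, so it is the least tolerated of the set; its gaps to compound 3 and to compound 1 both lie beyond the usual scatter. None of these three pairs differs in only one place, so no single step can be read from them.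

Compound 4 `CC1(c2ccc(-c3cccc([N+](=O)[O-])c3)cc2)CC(S(=O)(=O)c2ccc(F)cc2)=C(c2ccc(/C(N)=N\O)cc2)O1` is compound 2 with one change: a group of 9 heavy atoms (6 carbon, 1 nitrogen, 2 oxygen; one six-membered aromatic ring of carbon only) in place of a group of 10 heavy atoms (7 carbon, 2 nitrogen, 1 oxygen; one six-membered aromatic ring of carbon only), on an aromatic carbon. This leaves compound 4, like compound 1 and compound 3, carrying a single amidoxime, whereas compound 2 carries two. Going by the values given here, the data give no step of this exact kind. The expectation is a modest rise in this assay, a 1.9-fold higher number from compound 2 to compound 4 (0.28 log units; within the scatter), towards the numbers of compound 1 and compound 3, with the uncertainty wide. For compound 4 the estimated value in this assay is 7500 nM, expected to fall between 2500 nM and 22000 nM.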

Compound 4, half-maximal cytotoxic concentration: 11100 nM
For compound 4 the middle estimate is 1.5-fold (0.17 log units) below the measured one; measured number inside the range.
By their numbers in this assay, from the lowest: compound 2; then compounds 4, 3 and 1 (each within the scatter of the next).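

In this assay, the aromatic carbon para to a large group proves to be a place where a single change registers: putting 3-nitrophenyl in place of the group carrying the second amidoxime gives a 2.8-fold higher number from compound 2 to compound 4 (0.45 log units; beyond the scatter). Going by these compounds alone, this is the first change in the set confined to one place, so the shift can be tied to this position and not to several differences at once. Nothing measured here explains why the number moves.

On these data alone, this one swap removes an amidoxime and adds a nitro group together, so the share of each in the step stays unknown. As far as these compounds go, whether a plain phenyl, an aminophenyl or a benzoic acid at this position would match 3-nitrophenyl also remains open.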